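The compounds below may be only part of what the source reports. "The series", "measured", "known", "first", "only" and "open" are said of these compounds alone.

Measured compounds:
Compound 1, `N#Cc1ccc(NC(=O)NCc2cnc3scc(-c4ccc(Br)cc4)n23)cc1`: 97%
Compound 2, `CN(CC(=O)NCc1cnc2scc(-c3ccc(Br)cc3)n12)C(=O)c1ccc(C#N)cc1`: 47%

In an assay on isolated protein for inhibition of Indoleamine 2,3-dioxygenase 1 (Homo sapiens), with a stated time of 60 min, tested at 1 uM (a lower number here means less inhibition, a higher number more inhibition at the concentration tested (going by the name of the read-out)), compound 1 gives 97%. Compound 2 gives 47%, the lowest of the two numbers, and the gap to compound 1 is beyond the scatter. Going by the values given here, the two compounds differ in more than one place, so their two values say only that compound 2 inhibits less at the tested concentration, not which part of the structure accounts for it.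

Compound 3, `COc1cccc(C(=O)N(C)CC(=O)NCc2cnc3scc(-c4ccc(Br)cc4)n23)c1`, has not yet been measured in this assay. It differs from compound 2 in a single place: 3-methoxyphenyl in place of 4-cyanophenyl on a carbonyl carbon. Both the leaving and the entering group are a six-membered aromatic ring of carbon only; what changes is the substituent on that ring, a nitrile giving way to a methoxy group.

Among the compounds with values here, no measured pair shows this kind of exchange, so the expectation rests on compound 2 alone. The step from compound 2 to compound 3 is expected to be a small decrease, possibly none beyond the scatter, a number 12 percentage points lower from compound 2 to compound 3 (beyond the scatter). Compound 3 is therefore estimated at 35%, within a range of 10% to 60%.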

Compound 3, a percentage reported as inhibition, at one concentration (the size of the read-out at that concentration, not a potency): 48%
Compound 3: the middle estimate sits 13 percentage points below what was measured, within the range that was stated.
By their numbers in this assay, from the lowest: compounds 2 and 3 (each within the scatter of the next); then compound 1.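

In this assay, putting 3-methoxyphenyl in place of 4-cyanophenyl on a carbonyl carbon gives a number 1 percentage points higher from compound 2 to compound 3 (within the scatter). Going by these compounds alone, this is the first comparison here between compounds that differ in only one place, and it shows that, on this carbonyl carbon, the read-out does not separate a six-membered aromatic ring of carbon only bearing a nitrile from one bearing a methoxy group, at least for these two groups. No measurement at hand explains why the two compounds read alike.

The compounds shown leave open whether the same holds for a group of another kind on this carbonyl carbon, such as an unsubstituted phenyl ring, a simple methyl group, an amine or a carboxylic acid. They also leave open which structural difference separates compound 1 at 97% from compound 2 at 47%, as those two compounds differ in more than one place, so the urea-bearing side chain of compound 1 cannot yet be compared directly with the chain shared by compound 2 and compound 3.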